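A Chain Change Awaiting Its Measurement

The source may report more compounds than this note shows. Statements on the series, on what has been measured and on what is new or still open speak of the compounds shown alone.

In a functional assay on MCF7 cells (Homo sapiens) for cytotoxicity, read by MTT assay, with a stated time of 72 h (a higher number here means a weaker inhibitor, a lower number a stronger inhibitor), compound 1 `[O-][S+](CCCN=C=S)Cc1ccccc1` gives 7920 nM and compound 2 `CC(C)[S+]([O-])CCCN=C=S` gives 7930 nM, so the two stand within the scatter of each other. Compound 3 `[O-][S+](CCCCCCN=C=S)Cc1ccccc1` departs from compound 1 through one change, (a group of 6 heavy atoms (4 carbon, 1 nitrogen, 1 sulfur; no ring) in place of a group of 3 heavy atoms (1 carbon, 1 nitrogen, 1 sulfur; no ring), on a saturated chain carbon, three bonds along the chain from a sulfur), on a saturated chain carbon, three bonds along the chain from a sulfur. Going by the values given here, no measured pair yet shows the effect of such a change. A moderate step towards a stronger inhibitor is nonetheless expected in this assay, and the expected step is a 1.8-fold lower number from compound 1 to compound 3 (0.25 log units; within the scatter). For compound 3 the estimated value is 4500 nM, with an expected range of 1800 nM to 10000 nM.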

Compound 3, half-maximal inhibitory concentration: 5490 nM
The estimate for compound 3 lay 1.2-fold (0.09 log units) below the measured number, within the range that was stated.
By their numbers in this assay, from the lowest: compounds 3, 1 and 2 (each within the scatter of the next).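

Going by these compounds alone, this is the first measured step at this position. In this assay, the group of 6 heavy atoms in place of the group of 3 heavy atoms, on a saturated chain carbon, three bonds along the chain from a sulfur, gives a 1.4-fold lower number from compound 1 to compound 3 (0.16 log units; within the scatter), so the two compounds cannot be told apart, and the change is tolerated without a step beyond the scatter. No supporting data accompany this result to explain it.

One step cannot define a trend along the chain. Going by these compounds, whether a longer chain, or an amine at this position, would move the number beyond the scatter remains open.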